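The source may report more compounds than this note shows. Statements on the series, on what has been measured and on what is new or still open speak of the compounds shown alone.

Measured so far, in a functional assay on PC-3 cells (Homo sapiens) for cytotoxicity, read by MTT assay, with a stated time of 72 h; a lower number here means a stronger inhibitor, a higher number a weaker inhibitor:
compound 1 `CCCCCCNc1nc(SCc2ccc(C(F)(F)F)cc2)nc2ccccc12`: 19000 nM
compound 2 `FC(F)(F)c1ccc(CSc2nc(Nc3ccccc3C(F)(F)F)c3ccccc3n2)cc1`: 34800 nM
compound 3 `FC(F)(F)c1ccc(CSc2nc(Nc3cccc(Cl)c3)c3ccccc3n2)cc1`: 13400 nM

Compound 1 gives the second highest of the three numbers; its nearest neighbour is compound 3, a 1.4-fold lower number from compound 1 to compound 3 (0.15 log units; within the scatter), and its furthest is compound 2, a 1.8-fold higher number from compound 1 to compound 2 (0.26 log units; within the scatter), both within the scatter. Compound 4 `COc1ccc(Nc2nc(SCc3ccc(C(F)(F)F)cc3)nc3ccccc23)cc1OC` has not yet been run in this assay. It differs from compound 1 in one place: 3,4-dimethoxyphenyl in place of hexyl on a nitrogen on an aromatic ring. The two measured steps that bear on this both replace hexyl on the same nitrogen, and neither moved the number beyond the scatter. The same is therefore expected here. Compound 4 is expected to show no step beyond the scatter, a 1.1-fold lower number from compound 1 to compound 4 (0.05 log units; within the scatter). The estimate for compound 4 is 17000 nM, within 7000 nM to 40000 nM.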

Compound 4, half-maximal inhibitory concentration: 14100 nM
Compound 4: middle estimate off by 1.2-fold (0.08 log units), on the high side, within the range that was stated.
By their numbers in this assay, from the lowest: compounds 3, 4, 1 and 2 (each within the scatter of the next, the first and the last beyond it).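

In this assay, 3,4-dimethoxyphenyl on this nitrogen stays within the scatter of hexyl (a 1.3-fold lower number from compound 1 to compound 4 (0.13 log units; within the scatter)) and of 3-chlorophenyl (a 1.1-fold higher number from compound 3 to compound 4 (0.02 log units; within the scatter)). Only 2-(trifluoromethyl)phenyl stands apart from it (a 2.5-fold lower number from compound 2 to compound 4 (0.39 log units; beyond the scatter)), as it does from 3-chlorophenyl, although compound 2 remains within the scatter of hexyl compound 1. No measurement shown accounts for these steps.

As far as these compounds go, whether an unsubstituted phenyl, a 2-methoxyphenyl or a basic amine on a chain at this nitrogen would leave this narrow band remains open. So does whether the 2-(trifluoromethyl)phenyl gap would hold up on repeat.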